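Difluorophenyl Ketone in a Lung Carcinoma Growth Assay

The compounds below may be only part of what the source reports. "The series", "measured", "known", "first", "only" and "open" are said of these compounds alone.

Compound 1 `COc1cc(-c2cc(/C=C/C(=O)c3ccc(N)cc3)[nH]n2)cc(OC)c1OC`: 3510 nM
Compound 2 `COc1ccc(-c2cc(/C=C/C(=O)c3cc(OC)c(OC)c(OC)c3)[nH]n2)cc1OC`: 7910 nM

Of the compounds shown here, two have been measured in a functional assay on NCI-H226 cells (Homo sapiens) for inhibition, read by sulforhodamine B assay, with a stated time of 48 h; a higher number here means a weaker inhibitor of growth, a lower number a stronger inhibitor of growth. Compound 1 gives 3510 nM, the lowest of the two numbers. Compound 2 gives 7910 nM, a higher number, and the gap between the two values lies beyond the usual scatter. Among the compounds with values here, since compound 1 and compound 2 differ in more than one place, no single-change step is available to guide the next comparison.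

Compound 3 `COc1cc(-c2cc(/C=C/C(=O)c3ccc(F)c(F)c3)[nH]n2)cc(OC)c1OC` has not yet been measured. It differs from compound 1 in one place: 3,4-difluorophenyl in place of 4-aminophenyl on a carbonyl carbon. Within the data shown here, with no comparable step among the measured compounds, the expected size of this change rests on compound 1 alone, at 3510 nM, and the expectation is a small move to a weaker result, possibly within the scatter. The step expected from this change is a 1.4-fold higher number from compound 1 to compound 3 (0.15 log units; within the scatter). Compound 3 is therefore expected to give about 5000 nM, with a range from 1500 nM to 16000 nM.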

Compound 3, concentration for total growth inhibition: 15800 nM
For compound 3 the middle estimate is 3.2-fold (0.50 log units) below the measured one; measured number inside the range.
By their numbers in this assay, from the lowest: compound 1; then compounds 2 and 3 (each within the scatter of the next).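

In this assay, the group on the carbonyl carbon now has its first single-change step, and the result is not neutral: 3,4-difluorophenyl in place of 4-aminophenyl gives a weaker result (a 4.5-fold higher number from compound 1 to compound 3 (0.65 log units; beyond the scatter)). The group that leaves carries a hydrogen-bond donor and a hydrogen-bond acceptor, while the group that enters carries neither, but this one step cannot separate the loss of the amine from the arrival of the two fluorines. No measurement here explains the change.

The compounds shown leave open whether the amine itself matters, which an unsubstituted phenyl, a 4-fluorophenyl or a 4-hydroxyphenyl on the same carbonyl carbon could help to separate. They also leave open whether the same change would have a similar effect on a different core.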